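Replacing the Carboxyphenoxy Group in a Bile Acid Receptor Series

The source may hold more compounds than are shown below. What is called first, only, known or untested is meant among the compounds shown, and "the series" means these compounds.

Compound 1 `COc1ccc(Oc2ccc([C@H]3S[C@@H](C)C(=O)Nc4c3c(C)nn4-c3ccccc3C)cc2)cc1` gives 2200 nM in an assay on isolated protein for agonist activity at Bile acid receptor (Homo sapiens), read by AlphaScreen, with a stated time of 30 min; a lower number here means that less compound is needed, a higher number that more compound is needed for the effect. Its two acid-bearing relatives give no number: compound 2 `Cc1ccccc1-n1nc(C)c2c1NC(=O)[C@H](C)S[C@@H]2c1ccc(Oc2cccc(C(=O)O)c2)cc1` is reported as "not active" (no number reported) in this assay, and compound 3 `Cc1ccccc1-n1nc(C)c2c1NC(=O)[C@H](C)S[C@@H]2c1ccc(Oc2ccc(C(=O)O)cc2)cc1` likewise comes out as "not active" (no number reported) in this assay. So compound 3 stands without a value, only with the report that it showed no effect. Compound 4 `COc1ccccc1-c1ccc([C@H]2S[C@@H](C)C(=O)Nc3c2c(C)nn3-c2ccccc2C)cc1` has not yet been tested. It differs from compound 3 in one place: 2-methoxyphenyl in place of 4-carboxyphenoxy on an aromatic carbon. Compound 3 gave no number, so no step size can be computed, but a return to measurable activity in this assay is expected, with compound 4 being closer in shape to compound 1, which reached 2200 nM. Compound 4 is therefore estimated at 3000 nM, within 800 nM to 15000 nM.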

Compound 4, half-maximal effective concentration: 1100 nM
Compound 4: the middle estimate sits 2.7-fold (0.44 log units) above what was measured; the range from low to high includes it.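

In this assay compound 4 gives a measurable number, while compound 3, with 4-carboxyphenoxy at this place, gave none. The change to 2-methoxyphenyl gives a 2.0-fold lower number from compound 1 to compound 4 (0.30 log units; within the scatter), so this place accepts either methoxy-bearing group about equally, and the ring oxygen link of compound 1 is not required for activity at this level. Neither group brings the number far below the micromolar level seen here.

Nothing shown explains why the acid-bearing compounds gave no number. As far as these compounds go, whether an amine or a longer chain in place of the methoxy group would be accepted also stays open.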